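Thiophen-3-yl to Phenyl: Will Compound 4 Register?

The compounds below may be only part of what the source reports. "The series", "measured", "known", "first", "only" and "open" are said of these compounds alone.

Compound 1, `Nc1nc(N)c2c(-c3ccsc3)cn([C@@H]3O[C@H](CO)[C@@H](O)[C@H]3O)c2n1`, in an ADME assay on BJ cells (Homo sapiens), read by MTT assay, with a stated time of 72 h (on this read-out higher numbers stand for weaker inhibition and lower numbers for stronger inhibition), gives > 100000 nM; this is a limit of the assay, not a number.
Compound 2, `COc1ncnc2c1c(-c1ccco1)cn2[C@@H]1O[C@H](CO)[C@@H](O)[C@H]1O`, in this assay gives 430 nM.
Compound 3, `O=c1[nH]cnc2c1c(-c1ccsc1)cn2[C@@H]1O[C@H](CO)[C@@H](O)[C@H]1O`, in this assay gives > 100000 nM, again a limit of the assay rather than a number.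

Compound 1 therefore stands at the limit of > 100000 nM in this assay, at which 2 of the 3 values shown sit: no inhibition of cell growth was detected up to the highest concentration tested. For the measured compounds named here, compound 2 is the only one of the three with a measured number, but it differs from compound 1 in more than one place, so no single step can be drawn between them; all that the two values show is that compound 2 gives a number where compound 1 gives a limit.

Compound 4, `Nc1nc(N)c2c(-c3ccccc3)cn([C@@H]3O[C@H](CO)[C@@H](O)[C@H]3O)c2n1`, differs from compound 1 by phenyl in place of thiophen-3-yl on an aromatic carbon. Going by the values given here, nothing among the measured compounds traces the effect of this exchange on its own, and compound 1 and compound 3 together suggest that this shared core tends to sit at the limit. Compound 4 is thus expected to show a step of a number no higher from compound 1 to compound 4 (the limit leaves the size open), none beyond the scatter, most likely ending as a limit once more. Compound 4 is estimated at about 100000 nM, somewhere between 20000 nM and 300000 nM.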

Compound 4, half-maximal inhibitory concentration: > 100000 nM
Compound 4 ended at the assay's limit; the forecaster's own chance of this, stated with the estimate: 70%; the middle value sits exactly at the limit.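

In this assay, compound 1 and compound 4 each end at a limit of the assay rather than at a number, so no step can be read for phenyl in place of thiophen-3-yl. The compounds shown leave open how large this exchange's effect is, and whether any group at this place would give the shared core a measured number.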